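Swapping Benzyl for 4-Methylphenyl on the Amide Nitrogen

The source may report more compounds than this note shows. Statements on the series, on what has been measured and on what is new or still open speak of the compounds shown alone.

Of the compounds shown here, two have so far been measured in a functional assay on the whole organism (Ear) for inhibition, with Mus musculus as the target, at a dose of 40 mg/kg by the oral route; on this read-out higher numbers stand for more inhibition at the one dose given (going by the name of the read-out) and lower numbers for less inhibition. Compound 1, `O=C(Oc1ccc(-c2ccc(F)cc2F)cc1C(=O)O)c1ccccc1`, gives 16.1% in this assay. Compound 2, `CC(=O)Oc1ccc(-c2ccc(F)cc2F)cc1C(=O)NCc1ccccc1`, gives 34.1% in this assay, the higher of the two numbers, and its gap to compound 1 lies beyond the usual scatter of repeated measurements, so compound 2 stands clearly on top among the compounds measured. Among the compounds with values here, no two measured compounds differ in only one place, so the effect of any single structural change is still unknown here.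

Compound 3, `CC(=O)Oc1ccc(-c2ccc(F)cc2F)cc1C(=O)Nc1ccc(C)cc1`, is the next to be measured. Against compound 2 it shows (4-methylphenyl in place of benzyl on an amide-type nitrogen); the two compounds contain the same atoms joined differently. Within the data shown here, with no measured step of this kind to lean on, the expectation for compound 3 is drawn from compound 2 alone, whose value of 34.1% is the closest anchor. The step from compound 2 to compound 3 in this assay is expected to be a number 2.1 percentage points lower from compound 2 to compound 3 (within the scatter), that is, no change beyond the scatter. Compound 3 is therefore estimated to give 32% in this assay, with a range from 12% to 52%.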

Compound 3, a percentage reported as inhibition, in the whole organism at one dose (the size of the read-out at that dose, not a potency): 36.4%
Estimate against measurement, compound 3: 4.4 percentage points below; measured number inside the range.
By their numbers in this assay, from the lowest: compound 1; then compounds 2 and 3 (each within the scatter of the next).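

In this assay the first single-place change among these compounds, 4-methylphenyl in place of benzyl on an amide-type nitrogen, gives a number 2.3 percentage points higher from compound 2 to compound 3 (within the scatter), so this read-out does not tell the two groups apart at the one dose given. The change rearranges the same atoms, and both groups count the same heavy atoms and one six-membered aromatic ring of carbon only, so at this position the benzylamino and (4-methylphenyl)amino arrangements cannot be separated by this number. Nothing shown here gives a measured property that bears on this result, and no explanation can be offered for it.

The compounds shown leave open whether anything other than these two carbon groups would move the number at this nitrogen, for instance an amine, a carboxylic acid or a longer chain in the same place. They also leave open what each part of the difference between compound 1 and the other two contributes, since compound 1 differs from them in more than one place.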